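Replacing the 2-Aminobutoxy Group of Compound 2

The compounds below may be only part of what the source reports. "The series", "measured", "known", "first", "only" and "open" are said of these compounds alone.

In a functional assay on MCF7 cells (Homo sapiens) for inhibition, read by fluorescence, with a stated time of 72 h (on this read-out higher numbers stand for weaker inhibition and lower numbers for stronger inhibition), compound 1 (`CC(C)n1cnc2c(N)nc(N)nc21`) gives > 100000 nM as a limit of the assay, not a number. Compound 2 (`CC[C@@H](N)COc1nc(NC(=N)N)c2ncn(C(C)C)c2n1`) gives > 100000 nM in this assay as well, again only a limit, so its standing is known only as a bound. Compound 3 (`CC(C)[C@H](CO)Nc1nc(NC(=N)N)c2ncn(C(C)C)c2n1`) carries (1-(hydroxymethyl)-2-methylpropyl)amino in place of 2-aminobutoxy on an aromatic carbon. Within the data shown here, no measured step guides the size of this change. A small shift towards stronger inhibition in this assay is expected, with the estimated step of an at least 1.4-fold lower number from compound 2 to compound 3 (0.15 log units; that floor lies within the scatter) and the result possibly staying at the limit. For compound 3 the estimated value is 70000 nM within a range of 20000 nM to 150000 nM here.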

Compound 3, half-maximal inhibitory concentration: 10500 nM
Compound 3: the middle estimate sits 6.7-fold (0.82 log units) above what was measured, and the stated range ends above it.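

At this position, on an aromatic carbon between two ring nitrogen atoms, the side chain decides whether this assay gives a number at all. Putting (1-(hydroxymethyl)-2-methylpropyl)amino in place of 2-aminobutoxy gives an at least 9.5-fold lower number from compound 2 to compound 3 (0.97 log units; beyond the scatter), and compound 3 is the first compound shown to leave the limit. The true size of the step stays unknown because compound 2 gives only a bound: the limit of > 100000 nM in this assay, at which 2 of the 3 values shown sit.

The compounds shown leave open whether the ring-bound amino link or the hydroxymethyl-bearing branched chain carries this step. On these data alone, how a simple amine or a longer chain would read at this position also remains open.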